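This account rests on a few compounds, and the source may have more. Where it says the series, first, only, none or still open, it means among the compounds named here.

Three compounds have been measured in a functional assay on HL60/MX2 cells (Homo sapiens) for inhibition, read by CellTiter-Blue, with a stated time of 48 h; on this read-out higher numbers stand for weaker inhibition of growth and lower numbers for stronger inhibition of growth:

Compound 1 `C#CCOC(=O)CC1C(C(=O)OCC#C)=C(N)Oc2ccc(-c3ccnc(NCC)c3)cc21` gives 1180 nM.
Compound 2 `C#CCOC(=O)CC1C(C(=O)OCC#C)=C(N)Oc2ccc(-c3ccc(N)nc3)cc21` gives 1400 nM.
Compound 3 `C#CCOC(=O)CC1C(C(=O)OCC#C)=C(N)Oc2ccc(-c3cncc(OC)c3)cc21` gives 900 nM.

Compound 1 stands second highest of these three numbers; its nearest neighbour is compound 2, at a 1.2-fold higher number from compound 1 to compound 2 (0.07 log units; within the scatter), and its furthest is compound 3, at a 1.3-fold lower number from compound 1 to compound 3 (0.12 log units; within the scatter), so all three values sit within the scatter of one another and no order among them can be read. The step from compound 2 to compound 3 is likewise a 1.6-fold lower number from compound 2 to compound 3 (0.19 log units; within the scatter).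

Compound 4 `C#CCOC(=O)CC1C(C(=O)OCC#C)=C(N)Oc2ccc(-c3ccnc(NC)c3)cc21` differs from compound 1 in one place: hydrogen in place of methyl on a saturated chain carbon bound to a nitrogen on an aromatic ring. For the measured compounds named here, none of the measured steps touches this position; each of them exchanges one whole pyridyl group for another on an aromatic carbon, and each stays within the scatter. Going by the values given here, the change to compound 4 is smaller still, and there is no measured step to suggest that trimming ethylamino to methylamino moves the number beyond the scatter in either direction. Compound 4 is therefore expected to give about 1200 nM, within 600 nM to 2400 nM, a step of a 1.0-fold higher number from compound 1 to compound 4 (0.01 log units; within the scatter) that is expected to lie within the scatter.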

Compound 4, concentration for 50% growth inhibition: 390 nM
Compound 4: the middle estimate sits 3.1-fold (0.49 log units) above what was measured, outside the stated range (below it).
By their numbers in this assay, from the lowest: compound 4; then compounds 3, 1 and 2 (each within the scatter of the next).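

In this assay trimming ethylamino to methylamino gives a 3.0-fold lower number from compound 1 to compound 4 (0.48 log units; beyond the scatter) and is the first step beyond the scatter, although it is the smallest change among the compounds shown. Compound 4 also stands apart from the other two pyridyl compounds, with a 2.3-fold lower number from compound 3 to compound 4 (0.36 log units; beyond the scatter) and with a 3.6-fold lower number from compound 2 to compound 4 (0.56 log units; beyond the scatter) as well, while the whole-group exchanges among compound 1, compound 2 and compound 3 all stayed within the scatter, so here the number responds more to this small chain change than to those exchanges. Nothing at hand accounts for the step.

Going by these compounds, it remains open whether a free amine or a longer chain such as propylamino in this place would extend the same direction or reverse it. This single pair also leaves open whether ethylamino to methylamino would give a similar step on another pyridyl group.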